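Sulfonyl aryl swap on the indole-bearing core

This account rests on a few compounds, and the source may have more. Where it says the series, first, only, none or still open, it means among the compounds named here.

Compound 1 `Cn1c(=O)c(S(=O)(=O)c2ccc(Cl)cc2Cl)cc2cnc(Nc3ccc4[nH]ccc4c3)nc21` stands second highest of the three numbers in a functional assay on K562 cells (Homo sapiens) for inhibition, read by trypan blue exclusion, with a stated time of 72 h (a higher number here means a weaker inhibitor, a lower number a stronger inhibitor), where compound 1 gives 1000 nM. The nearest value belongs to compound 2 `Cn1c(=O)c(S(=O)(=O)c2ccc(F)cc2F)cc2cnc(Nc3ccc4sccc4c3)nc21`, which in this assay gives 500 nM, within the scatter of compound 1. The furthest is compound 3 `Cn1c(=O)c(S(=O)(=O)c2ccc(F)cc2F)cc2cnc(Nc3ccc4c(c3)CC(=O)N4)nc21`, which gives 15000 nM. Among the compounds with values here, the one single-point step measured, a 30-fold higher number from compound 2 to compound 3 (1.48 log units; beyond the scatter), changes the group on the aromatic ring nitrogen, not the sulfonyl aryl. Within the data shown here, compound 1 and compound 2 differ in two places at once, so their two values show only that the pair lies close together.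

Compound 4 `Cn1c(=O)c(S(=O)(=O)c2ccc(N)cc2F)cc2cnc(Nc3ccc4[nH]ccc4c3)nc21` differs from compound 1 by 4-amino-2-fluorophenyl in place of 2,4-dichlorophenyl on a sulfonyl sulfur. Among the measured compounds shown here, no measured step touches the group on the sulfonyl sulfur, so the change stands without a direct precedent; the only pair that crosses it, compound 1 and compound 2, sits within the scatter while also differing elsewhere. The expectation for this assay is therefore no step beyond the scatter, no change at the digits printed from compound 1 to compound 4 (within the scatter). Compound 4 is estimated at 1000 nM, with a range from 300 nM to 4000 nM.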

Compound 4, half-maximal inhibitory concentration: 1500 nM
Compound 4: middle estimate off by 1.5-fold (0.18 log units), on the low side; the measured number falls inside the stated range.
By their numbers in this assay, from the lowest: compounds 2, 1 and 4 (each within the scatter of the next, the first and the last beyond it); then compound 3.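

In this assay, the group on the sulfonyl sulfur now has its first single-point reading, a 1.5-fold higher number from compound 1 to compound 4 (0.18 log units; within the scatter), for 4-amino-2-fluorophenyl in place of 2,4-dichlorophenyl. With the rest of compound 1 unchanged, this place accepts an aryl group carrying hydrogen-bond donor and acceptor counts in place of one with none, and the step stays within the scatter. No measurement here bears on why the two groups read alike.

The compounds shown leave open how far this tolerance extends on the sulfonyl sulfur, for example to an unsubstituted phenyl, a carboxylic acid-bearing phenyl or a short alkyl chain such as ethyl. They also leave open which part of the 4-amino-2-fluorophenyl group, the amino group or the fluorine, would give the same reading on its own.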